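Extending the sulfur substituent of compound 3

The source may hold more compounds than are shown below. What is called first, only, known or untested is meant among the compounds shown, and "the series" means these compounds.

Values measured in a functional assay on MCF7 cells (Homo sapiens) for inhibition, read by MTT assay, with a stated time of 72 h (a lower number here means a stronger inhibitor, a higher number a weaker inhibitor), for three compounds:
- compound 1 `CN1CCN(c2cc(C(F)(F)F)nc(SCc3ccc(C(F)(F)F)cc3)n2)CC1` gives 30200 nM
- compound 2 `CCN1CCN(c2cc(C(F)(F)F)nc(SCc3ccc(C(F)(F)F)cc3)n2)CC1` gives 22000 nM
- compound 3 `FC(F)(F)c1ccc(CSc2nc(Sc3ccccn3)cc(C(F)(F)F)n2)cc1` gives 43200 nM

Compound 3 cannot be separated from the other two, as its steps show: a 1.4-fold higher number from compound 1 to compound 3 (0.16 log units; within the scatter) and a 2.0-fold higher number from compound 2 to compound 3 (0.29 log units; within the scatter) both remain within the scatter. The next compound is compound 4 `FC(F)(F)c1ccc(CSc2nc(Sc3ncc(-c4ccncc4)s3)cc(C(F)(F)F)n2)cc1` in which 5-(pyridin-4-yl)-1,3-thiazol-2-yl stands in place of pyridin-2-yl on a sulfur 5-(pyridin-4-yl)-1,3-thiazol-2-yl in place of pyridin-2-yl on a sulfur and the rest of compound 3 is kept.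

Among the measured compounds shown here, no measured compound carries the entering group, so the evidence is indirect. The largest measured exchange, a 2.0-fold higher number from compound 2 to compound 3 (0.29 log units; within the scatter) stayed within the scatter, and so did a 1.4-fold lower number from compound 1 to compound 2 (0.14 log units; within the scatter) on the chain. Nothing measured therefore points to a clear shift in this assay in either direction. The step expected is a 1.7-fold lower number from compound 3 to compound 4 (0.24 log units; within the scatter) with the uncertainty wide for so new a group. Compound 4 is expected at 25000 nM (estimated range 6000 nM to 55000 nM).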

Compound 4, half-maximal inhibitory concentration: 10100 nM
The estimate for compound 4 lay 2.5-fold (0.39 log units) above the measured number, and the stated range covers the measured number.
By their numbers in this assay, from the lowest: compound 4; then compounds 2, 1 and 3 (each within the scatter of the next).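

Replacing pyridin-2-yl with 5-(pyridin-4-yl)-1,3-thiazol-2-yl on the sulfur gives the only step among these compounds that lies beyond the scatter in this assay (a 4.3-fold lower number from compound 3 to compound 4 (0.63 log units; beyond the scatter)). The earlier exchanges had left the numbers within the scatter, whereas this one shows that the number responds to the group carried on this sulfur. Nothing available explains this step, and a single pair cannot divide it between the five-membered and six-membered aromatic rings that enter.

The compounds shown leave open whether the 1,3-thiazol-2-yl ring alone would give the same step, or whether a phenyl group could stand in place of the pyridin-4-yl. They also leave open how an amine or a carboxylic acid on the outer ring would read in this assay.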